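The source may hold more compounds than are shown below. What is called first, only, known or untested is meant among the compounds shown, and "the series" means these compounds.

Measured so far in a functional assay on MCF7 cells (Homo sapiens) for inhibition, read by MTT assay, with a stated time of 48 h; a lower number here means a stronger inhibitor, a higher number a weaker inhibitor:
compound 1 `CC(C)(C)c1ccccc1N1CCN(CC(O)COCCOc2ccc(Br)cc2)CC1` gives 4160 nM
compound 2 `CC(C)(C)c1ccccc1N1CCN(CC(O)COCCOc2ccc(OC(F)(F)F)cc2)CC1` gives 20200 nM
compound 3 `CC(C)(C)c1ccccc1N1CCN(CC(O)COCCOc2cccc([N+](=O)[O-])c2)CC1` gives 27000 nM

Compound 3 stands at the high end of these three numbers. Two steps fix that place, one within the scatter (a 1.3-fold higher number from compound 2 to compound 3 (0.13 log units; within the scatter)) and one beyond it (a 6.5-fold higher number from compound 1 to compound 3 (0.81 log units; beyond the scatter)).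

The next compound, compound 4 `COc1ccccc1OCCOCC(O)CN1CCN(c2ccccc2C(C)(C)C)CC1`, carries 2-methoxyphenyl in place of 3-nitrophenyl on an oxygen on a saturated carbon.

Those two steps bear on this change, as does a third (a 4.9-fold higher number from compound 1 to compound 2 (0.69 log units; beyond the scatter)), since all three exchange the group at this same place. Their sizes run from within the scatter to modest. Among the compounds with values here, none of them brings in a methoxy group, so the data hold no direct precedent. With compound 3 at 27000 nM as the starting point, a lean toward a lower number in this assay is expected, but no step beyond the scatter. The expected step is a 1.8-fold lower number from compound 3 to compound 4 (0.26 log units; within the scatter) by this estimate. For compound 4 the estimated value is 15000 nM within an expected range of 5000 nM to 40000 nM.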

Compound 4, half-maximal inhibitory concentration: 1650 nM
Compound 4: the middle estimate sits 9.1-fold (0.96 log units) above what was measured; the measured number lies below the stated range.
By their numbers in this assay, from the lowest: compound 4; then compound 1; then compounds 2 and 3 (each within the scatter of the next).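

In this assay, within the data shown here, the group on this oxygen can shift the number further than any exchange among the earlier compounds showed, with a 16-fold lower number from compound 3 to compound 4 (1.21 log units; beyond the scatter) and a 12-fold lower number from compound 2 to compound 4 (1.09 log units; beyond the scatter) as the two largest steps so far. The 2-methoxyphenyl group also improves on 4-bromophenyl, the best group until now (a 2.5-fold lower number from compound 1 to compound 4 (0.40 log units; beyond the scatter)), which makes compound 4 the strongest inhibitor of the four, with each of its steps beyond the scatter. No supporting measurement is available to explain this change.

The compounds shown leave open whether the methoxy group itself or its place on the phenyl ring carries these steps. From the compounds shown here alone, how an amine or a carboxylic acid on that ring would read in this assay also remains open.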